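Sulfamoylurea series: varying the sulfonyl nitrogen substituents

The source may report more compounds than this note shows. Statements on the series, on what has been measured and on what is new or still open speak of the compounds shown alone.

Measured compounds:
compound 1 `CC(C)NS(=O)(=O)NC(=O)Nc1c(C(C)C)cccc1C(C)C` 18000 nM
compound 2 `CCN(CC)S(=O)(=O)NC(=O)Nc1c(C(C)C)cccc1C(C)C` 2500 nM
compound 3 `CCCCN(C)S(=O)(=O)NC(=O)Nc1c(C(C)C)cccc1C(C)C` 2300 nM

In an assay on liver for inhibition of sterol O-acyltransferase 1 (Rattus norvegicus), using microsomes (a lower number here means a stronger inhibitor, a higher number a weaker inhibitor), compound 3 gives the lowest of the three numbers, yet it stands within the scatter of compound 2, so no order between these two can be read; only compound 1 is clearly separated, by a 7.8-fold lower number from compound 1 to compound 3 (0.89 log units; beyond the scatter) and a 7.2-fold lower number from compound 1 to compound 2 (0.86 log units; beyond the scatter).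

Compound 4 `C=CCN(CC)S(=O)(=O)NC(=O)Nc1c(C(C)C)cccc1C(C)C` differs from compound 3 by allyl(ethyl)amino in place of butyl(methyl)amino on a sulfonyl sulfur. Among the compounds with values here, the one step that bears on this, an exchange of one disubstituted nitrogen for another, is a 1.1-fold lower number from compound 2 to compound 3 (0.04 log units; within the scatter). On that basis the change to compound 4 is expected to produce a 1.1-fold higher number from compound 3 to compound 4 (0.04 log units; within the scatter), with no step beyond the scatter in either direction. Compound 4 is therefore estimated at 2500 nM, within 1000 nM to 6000 nM.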

Compound 4, half-maximal inhibitory concentration: 2100 nM
Compound 4: the middle estimate sits 1.2-fold (0.08 log units) above what was measured; the range from low to high includes it.
By their numbers in this assay, from the lowest: compounds 4, 3 and 2 (each within the scatter of the next); then compound 1.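

In this assay, the double bond of the allyl group brings no separation from the saturated chains, either against diethylamino (a 1.2-fold lower number from compound 2 to compound 4 (0.08 log units; within the scatter)) or against butyl(methyl)amino (a 1.1-fold lower number from compound 3 to compound 4 (0.04 log units; within the scatter)). Allyl(ethyl)amino instead stands with these two groups, clear of isopropylamino (an 8.6-fold lower number from compound 1 to compound 4 (0.93 log units; beyond the scatter)). No supporting data bear on why this position shows this pattern.

Going by these compounds, whether butylamino, with its single chain on the nitrogen, would stand with isopropylamino or with the disubstituted groups remains open. Also open, on these data alone, is how a ring on this nitrogen, such as piperidine or morpholine, or a longer chain ending in a carboxylic acid would read.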